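A Single Methyl Group and Its Effect on Cell Growth

The source may hold more compounds than are shown below. What is called first, only, known or untested is meant among the compounds shown, and "the series" means these compounds.

Of the compounds shown here, three have been tested for their effect on the growth of cells. Compound 1 `N/C(=N\NC(=S)N1CCCCCC1)c1ccccn1` and compound 2 `N/C(=N\NC(=S)N1CCOCC1)c1ccccn1` are close relatives; the difference between their two cores is not broken down here. In a functional assay on MCF7 cells (Homo sapiens) for cytotoxicity, read by MTT assay, with a stated time of 72 h, tested at 10 uM (a lower number here means less inhibition of growth, a higher number more inhibition of growth at the concentration tested), compound 1 gives 62.2% and compound 2 gives 66.7%; these two numbers lie within the usual scatter of each other, so no order between them can be read.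

Compound 3 `Cc1ccnc(/C(N)=N/NC(=S)N2CCOCC2)c1` carries one change relative to compound 2: methyl in place of hydrogen on an aromatic carbon. In this assay compound 3 gives 6.86%, and the step is a number 59.8 percentage points lower from compound 2 to compound 3 (beyond the scatter).

Compound 4 `Cc1cccc(/C(N)=N/NC(=S)N2CCCCCC2)n1` is built from compound 1 by the same kind of change: methyl in place of hydrogen on an aromatic carbon. The surroundings of the new group are not identical, however. In compound 3 the methyl sits opposite the ring nitrogen, while in compound 4 it sits next to the ring nitrogen; in both it is meta to a large group.

Going by the values given here, only one such step has been measured, and it comes from a different position on the ring, so the expectation for compound 4 carries real uncertainty. Still, the step is expected to be a number 47.2 percentage points lower from compound 1 to compound 4 (beyond the scatter), a fall of the same direction, resting on a number 59.8 percentage points lower from compound 2 to compound 3 (beyond the scatter). Compound 4 is therefore estimated to give 15%, with a plausible range from 0% to 50%.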

Compound 4, percent growth inhibition at one concentration: 21.5%
Compound 4: middle estimate off by 6.5 percentage points, on the low side; low and high end bracket the measured number.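

In this assay, the step is a number 40.7 percentage points lower from compound 1 to compound 4 (beyond the scatter), so methyl in place of hydrogen on an aromatic carbon lowers growth inhibition on both cores shown, and the direction of the change carries over between them. The size of the fall does not carry over, however: the same change on two cores in this assay, a number 59.8 percentage points lower (beyond the scatter) from compound 2 to compound 3 and a number 40.7 percentage points lower (beyond the scatter) from compound 1 to compound 4, 19.1 percentage points apart, beyond the scatter of two such steps

These two steps do not show where that gap comes from, since the cores differ and the methyl of compound 4 sits next to the ring nitrogen while the methyl of compound 3 sits elsewhere on the ring, and with both differences present at once, neither can be singled out; two steps are also too few to support a rule for the whole series.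

The compounds shown leave open how each core would respond with the methyl placed as it is on the other, which would help separate the role of the core from that of the ring position. They also leave open whether the fall is particular to methyl or would also follow from another group at the same place, such as a fluorine atom, a methoxy group or an amine.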